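The source may report more compounds than this note shows. Statements on the series, on what has been measured and on what is new or still open speak of the compounds shown alone.

Measured compounds:
compound 1 `O=C(O)Cc1sc(COc2ccc(Cl)cc2)nc1-c1ccc(Cl)cc1` — 370 nM
compound 2 `O=C(O)Cc1sc(C(c2ccccc2)c2ccc(Cl)cc2)nc1-c1ccc(Cl)cc1` — 75 nM
compound 3 `O=C(O)Cc1sc(C(c2ccccc2)c2ccc(Cl)cc2)nc1-c1ccc(F)cc1` — 79 nM

In an in vitro functional assay on HEK285-7 cells for antagonist activity at prostaglandin D2 receptor 2 (Homo sapiens), read by BRET and beta-arrestin recruitment (on this read-out higher numbers stand for weaker inhibition and lower numbers for stronger inhibition), compound 3 stands second highest of the three numbers. Its nearest neighbour is compound 2, and the step of a 1.1-fold higher number from compound 2 to compound 3 (0.02 log units; within the scatter) is within the scatter; compound 1, whose value is 370 nM, lies furthest from it, and compound 1 and compound 3 differ in more than one place, so only their two values can be compared.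

Compound 4 `O=C(O)Cc1sc(C(c2ccccc2)c2ccc(O)cc2)nc1-c1ccc(F)cc1` is not yet measured. It differs from compound 3 by hydroxy in place of chloro on an aromatic carbon. Within the data shown here, no measured step bears directly on this change: the only step on a single position, from chloro to fluoro on the ring attached to the core, was within the scatter, and it touches a different ring from the one changed here. The data give no guide to a hydroxy at this place, so the expectation for compound 4 rests on the value of compound 3 alone, with a wide range. Compound 4 is expected at 200 nM, between 60 nM and 700 nM, which means an expected step of a 2.5-fold higher number from compound 3 to compound 4 (0.40 log units; beyond the scatter).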

Compound 4, half-maximal inhibitory concentration: 30 nM
Compound 4: middle estimate off by 6.7-fold (0.82 log units), on the high side; the whole stated range lies above it.
By their numbers in this assay, from the lowest: compound 4; then compounds 2 and 3 (each within the scatter of the next); then compound 1.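

In this assay, replacing 4-chlorophenyl with 4-hydroxyphenyl gives a 2.6-fold lower number from compound 3 to compound 4 (0.42 log units; beyond the scatter), the only single-place change among these compounds that lies beyond the scatter. This shows that the number at this position responds to the group on the ring, which the earlier chloro-to-fluoro step on the other ring could not show, and that a hydroxy, with one hydrogen-bond donor and one hydrogen-bond acceptor where chloro has neither, goes with stronger inhibition rather than weaker. Nothing measured here accounts for this difference.

The compounds shown leave open whether a methoxy or an amine at the same place would behave like the hydroxy. They also leave open whether a hydroxy on the fluorophenyl ring, or on the unsubstituted phenyl ring, would give a similar step.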